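The compounds below may be only part of what the source reports. "The series", "measured", "known", "first", "only" and "open" are said of these compounds alone.

For the measured compounds named here, compound 2 `O=C(OC1(C(=O)Nc2ccc([N+](=O)[O-])cc2)CCCCC1)c1ccc(Br)cc1` stands second highest of the three numbers so far in a functional assay on HepG2 cells (Homo sapiens) for inhibition, read by MTT assay, with a stated time of 72 h; a lower number here means a stronger inhibitor, a higher number a weaker inhibitor: compound 2 gives 284 nM, while compound 1 `O=C(OC1(C(=O)Nc2ccc([N+](=O)[O-])cc2)CCCCC1)c1ccc(C(F)(F)F)cc1` gives 29.1 nM and compound 3 `CC(=O)OC1(C(=O)Nc2ccc([N+](=O)[O-])cc2)CCCCC1` gives 519 nM. The path from compound 1 to compound 2 is a bromo in place of a trifluoromethyl on an aromatic carbon, with a 9.8-fold higher number from compound 1 to compound 2 (0.99 log units; beyond the scatter). Going by the values given here, the path from compound 1 to compound 3, a methyl in place of the 4-(trifluoromethyl)phenyl on a carbonyl carbon, shows an 18-fold higher number from compound 1 to compound 3 (1.25 log units; beyond the scatter), whereas the closest precedent, methyl in place of 4-bromophenyl on the carbonyl carbon, shows only a 1.8-fold higher number from compound 2 to compound 3 (0.26 log units; within the scatter).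

Compound 4 `CCC(=O)OC1(C(=O)Nc2ccc([N+](=O)[O-])cc2)CCCCC1` differs from compound 2 by ethyl in place of 4-bromophenyl on a carbonyl carbon. This change resembles the step to compound 3, since ethyl is only one carbon longer than methyl. The expectation is therefore a shift of roughly a 1.6-fold higher number from compound 2 to compound 4 (0.20 log units; within the scatter) in this assay, that is, little change beyond the scatter. For compound 4 the estimate is 450 nM, within a range of 200 nM to 1000 nM.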

Compound 4, half-maximal inhibitory concentration: 21.5 nM
Compound 4: the middle estimate sits 21-fold (1.32 log units) above what was measured; measured number below the stated range.
By their numbers in this assay, from the lowest: compounds 4 and 1 (each within the scatter of the next); then compounds 2 and 3 (each within the scatter of the next).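

In this assay, for the compounds shown here, this carbonyl carbon proves far more sensitive to small changes than the earlier compounds suggested: ethyl in place of 4-bromophenyl gives a 13-fold lower number from compound 2 to compound 4 (1.12 log units; beyond the scatter), and one added methyl on the saturated chain gives a 24-fold lower number from compound 3 to compound 4 (1.38 log units; beyond the scatter). Ethyl in place of 4-(trifluoromethyl)phenyl gives a 1.4-fold lower number from compound 1 to compound 4 (0.13 log units; within the scatter), so among these compounds an aromatic ring at this place is not required for a low number, and the number does not follow the size of the group, with methyl and ethyl lying far apart. No measurement at hand accounts for the gap between these two short chains.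

On these data alone, whether a longer chain such as butyl or a branched isopropyl keeps the number as low as ethyl remains open. So does the effect of an amine or a carboxylic acid carried on the ethyl chain.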